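Series notes: sulfonyl variation and the antiproliferative read-out

The source may hold more compounds than are shown below. What is called first, only, known or untested is meant among the compounds shown, and "the series" means these compounds.

Compound 1 `COc1ccc(-c2cc(=O)c3c(OC)cc(OC)cc3n2Cc2ccccc2)cc1`, compound 2 `COc1ccc(-c2cc(=O)c3c(OC)cc(OC)cc3n2S(=O)(=O)c2ccc(C=O)cc2)cc1` and compound 3 `COc1ccc(-c2cc(=O)c3c(OC)cc(OC)cc3n2S(=O)(=O)c2ccc(C)c([N+](=O)[O-])c2)cc1` share one core and differ only in the group on the aromatic nitrogen. In a functional assay on SUP-B15 cells (Homo sapiens) for antiproliferative activity, with a stated time of 72 h (a lower number here means that less compound is needed, a higher number that more compound is needed for the effect), compound 1 reaches only the limit > 34400 nM. Compound 2 likewise gives the limit > 34400 nM. Compound 3 returns the limit > 51700 nM. Accordingly the step that the two limits leave unreadable from compound 1 to compound 2 and the step that the two limits leave unreadable from compound 2 to compound 3 cannot be sized, since every value sits at a limit (the limit of > 34400 nM in this assay, at which 2 of the 3 values shown sit, (the limit of > 51700 nM in this assay, at which 1 of the 3 values shown sits)). Compound 4 `COc1ccc(-c2cc(=O)c3c(OC)cc(OC)cc3n2S(=O)(=O)c2ccc(C#N)cc2)cc1` differs from compound 3 by 4-cyanophenyl in place of 4-methyl-3-nitrophenyl on a sulfonyl sulfur. Going by the values given here, no measured step bears readably on this change, and the three values shown give no sign of activity, so no step beyond the scatter is expected in this assay and compound 4 is expected to stay at a limit. The estimate for compound 4 is 50000 nM (range 20000 nM to 200000 nM), an expected step of an at least 1.0-fold lower number from compound 3 to compound 4 (0.01 log units; that floor lies within the scatter).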

Compound 4, half-maximal effective concentration: 7900 nM
For compound 4 the middle estimate is 6.3-fold (0.80 log units) above the measured one, outside the stated range (below it).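

In this assay, the group on the sulfonyl sulfur now gives a readable step: 4-cyanophenyl in place of 4-methyl-3-nitrophenyl gives an at least 6.5-fold lower number from compound 3 to compound 4 (0.81 log units; beyond the scatter). Cyano in place of formyl on an aromatic carbon gives an at least 4.3-fold lower number from compound 2 to compound 4 (0.63 log units; beyond the scatter), and exchanging the benzyl group on the aromatic nitrogen for a (4-cyanophenyl)sulfonyl group gives an at least 4.3-fold lower number from compound 1 to compound 4 (0.63 log units; beyond the scatter). Each size is only a floor, the starting values being limits of the assay: the limit of > 34400 nM in this assay, at which 2 of the 4 values shown sit; the limit of > 51700 nM in this assay, at which 1 of the 4 values shown sits.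

The compounds shown leave open how far the cyano group itself carries the step. As far as these compounds go, an amine, a carboxylic acid or a trifluoromethyl group in its place on the aromatic carbon remains untested within this set.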